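Ethoxy on the shared core: cytotoxicity working notes

The source may report more compounds than this note shows. Statements on the series, on what has been measured and on what is new or still open speak of the compounds shown alone.

Compound 1 `C#CCNC1=CC(=O)c2cccc(OC)c2C1=O`: > 32000 nM
Compound 2 `C#CCNC1=CC(=O)c2cccc(OCc3ccccc3)c2C1=O`: > 64000 nM
Compound 3 `C#CCNC1=CC(=O)c2ccccc2C1=O`: > 64000 nM

In a functional assay on SH-SY5Y cells (Homo sapiens) for cytotoxicity, read by MTT assay, with a stated time of 24 h (on this read-out higher numbers stand for weaker inhibition and lower numbers for stronger inhibition), compound 3 gives > 64000 nM as a limit and not a number. Every value shown is a limit, with the limit of > 32000 nM in this assay, at which 1 of the 3 values shown sits, and the limit of > 64000 nM in this assay, at which 2 of the 3 values shown sit, covering the series. Compound 4 `C#CCNC1=CC(=O)c2cccc(OCC)c2C1=O` has ethoxy in place of hydrogen on an aromatic carbon of compound 3 (ethoxy in place of hydrogen on an aromatic carbon). The closest steps run the other way, a step that the two limits leave unreadable from compound 1 to compound 3 and a step that the two limits leave unreadable from compound 2 to compound 3 with hydrogen replacing methoxy and benzyloxy, and neither has a readable size. No step beyond the scatter is therefore expected. The expected size is a number no higher from compound 3 to compound 4 (the limit leaves the size open) in this estimate. In this assay the estimate for compound 4 is 64000 nM (expected range 32000 nM to 128000 nM) and a reported limit is likely.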

Compound 4, half-maximal inhibitory concentration: > 64000 nM
Compound 4: only a limit was reported; the forecaster's own chance of this, stated with the estimate: 85%; the middle value lies on the limit itself.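

The steps from compound 1, compound 2 and compound 3 to compound 4 cannot be read, as each pair gives only limits. The compounds shown leave open whether hydrogen, methoxy, ethoxy or benzyloxy on the shared core differ at all in this assay.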